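The source may hold more compounds than are shown below. What is called first, only, known or untested is meant among the compounds shown, and "the series" means these compounds.

Measured in an ADME assay on cells (Peritoneal macrophage, Mus musculus) for cytotoxicity, read by MTT assay, with a stated time of 24 h; a higher number here means that more compound is tolerated, a lower number that less compound is tolerated:
- compound 1 `O=C(/N=C(/NCc1ccccc1)Nc1ccc(F)cc1)c1ccccc1`: 866000 nM
- compound 2 `O=C(/N=C(/NCc1ccccc1)Nc1ccc([N+](=O)[O-])cc1)c1ccccc1`: 802000 nM

Not yet measured:
- compound 3 `O=C(/N=C(/NCc1ccccc1)Nc1ccccc1)c1ccccc1`

Within the data shown here, compound 2 gives 802000 nM, and this value lies within the usual scatter of the one for compound 1, 866000 nM. Compound 3 differs from compound 2 by one change, hydrogen in place of nitro on an aromatic carbon. Among the measured compounds shown here, only one measured step bears on this. It is a 1.1-fold lower number from compound 1 to compound 2 (0.03 log units; within the scatter), where nitro replaces fluoro on that same aromatic carbon, and it stayed within the scatter. For the measured compounds named here, no measured compound yet carries hydrogen there, so this evidence is thin. Even so, nothing shown points to a real shift in either direction. The expected result in this assay is a 1.0-fold higher number from compound 2 to compound 3 (0.01 log units; within the scatter), which means no step beyond the scatter. Compound 3 is expected near 830000 nM, with an estimated range from 450000 nM to 1400000 nM.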

Compound 3, half-maximal cytotoxic concentration: 35900 nM
Beside the measured number, compound 3's estimate is 23-fold (1.36 log units) above it; the measured number lies below the stated range.
By their numbers in this assay, from the lowest: compound 3; then compounds 2 and 1 (each within the scatter of the next).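

In this assay there is a 22-fold lower number from compound 2 to compound 3 (1.35 log units; beyond the scatter) and also a 24-fold lower number from compound 1 to compound 3 (1.38 log units; beyond the scatter) when the aromatic carbon carries only hydrogen. The earlier pair made this position look indifferent, since nitro and fluoro stayed within the scatter of each other, but the new result shows that having either group there, rather than hydrogen, goes with a much larger tolerated concentration among these compounds. Nothing measured here explains this difference.

Fluoro and nitro are very different groups, yet they give the same reading, so it remains open whether any group at this position would do the same. A methyl, a methoxy or an amine there could show whether the plain phenyl of compound 3 is the exception or whether the outcome depends on which group is present.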